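Acetyl to dimethylamino: from compound 1 to compound 4

A few compounds are considered here, and "the series" means these few. Any claim that something is new, unique, unknown or untested is made for them only; others in the source may bear on it.

compound 1 `COc1cc(C)cc(-c2c(-c3ccnc(-c4ccc(C(C)=O)cc4)c3)cnn2CC#N)c1`: 77%
compound 2 `COc1cc(C)cc(-c2nn(CC#N)cc2-c2ccc(-c3cccc(C(C)=O)c3)nc2)c1`: 60%
compound 3 `COc1cc(C)cc(-c2nn(CC#N)cc2-c2ccnc(-c3ccc(N(C)C)cc3)c2)c1`: 88%

In a functional assay on A498 cells (Homo sapiens) for cytotoxicity, read by sulforhodamine B assay, with a stated time of 48 h, tested at 0.01 uM (on this read-out lower numbers stand for a stronger effect and higher numbers for a weaker effect at the one concentration tested), compound 1 gives 77%, the second highest of the three numbers in hand. Compound 3 stands at 88%, a number higher than that of compound 1 by more than the scatter, while compound 2 stands at 60%, lower than compound 1 by more than the scatter. No two of these three compounds differ in one place only, so no single-change step can be read from them.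

Compound 4 `COc1cc(C)cc(-c2c(-c3ccnc(-c4ccc(N(C)C)cc4)c3)cnn2CC#N)c1` has not been measured. It differs from compound 1 as follows: dimethylamino in place of acetyl on an aromatic carbon. The change sits on an aromatic carbon of a six-membered aromatic ring of carbon only, para to a large group. Among the measured compounds shown here, the only measured compound that also carries a dimethylamino group is compound 3, which gives the highest number of the three with 88%, but it is not a one-place neighbour of compound 1 and the comparison is loose. The step from compound 1 to compound 4 in this assay is expected to be a number 8 percentage points higher from compound 1 to compound 4 (within the scatter), toward a higher number and small enough that it may stay within the scatter. Compound 4 is therefore expected to give about 85%, in a range from 72% to 96%.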

Compound 4, a percentage reported as activity, at one concentration (the size of the read-out at that concentration, not a potency): 40%
Beside the measured number, compound 4's estimate is 45 percentage points above it; the whole stated range lies above it.
By their numbers in this assay, from the lowest: compound 4; then compound 2; then compound 1; then compound 3.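

In this assay, among the compounds shown here, dimethylamino in place of acetyl on an aromatic carbon, para to a large group, gives a number 37 percentage points lower from compound 1 to compound 4 (beyond the scatter) and so runs toward the stronger effect; this is the first single-place step available. The position on this six-membered aromatic ring of carbon only is therefore not silent: the read-out responds to the group held there, at least for this pair. The step also arises between two groups with the same heavy-atom count, the same count of hydrogen-bond acceptors, no ring and no net charge, so those counts alone do not set the read-out at this position, and no measurement in hand explains the change.

With a single exchange at this position, the loss of acetyl and the entry of dimethylamino cannot be told apart, and a bare hydrogen, a primary amine, a methoxy group or a morpholine ring in the same place would help to separate them. Compound 2 and compound 3 have no one-place partner among the compounds shown, so no step can be read for either of them.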